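The source may report more compounds than this note shows. Statements on the series, on what has been measured and on what is new or still open speak of the compounds shown alone.

Compound 1 `CC1=C(C(=O)Nc2ccc([N+](=O)[O-])cc2)C(c2ccc(Br)cc2)N=C(SCc2ccc(F)cc2)N1` and compound 2 `CC1=C(C(=O)Nc2ccc([N+](=O)[O-])cc2)C(c2cccc([N+](=O)[O-])c2)N=C(SCc2ccccc2Cl)N1` share the same core and were both tested in a functional assay on the whole organism (artery, strain albino) with Rattus norvegicus as the target, with a stated time of 180 min, at a dose of 10 mg/kg by the oral route; a lower number here means less inhibition, a higher number more inhibition at the dose given (going by the name of the read-out). In this assay compound 1 gives 17.5%, and compound 2 gives 9.3%. Compound 2 holds the lower of the two numbers, yet its gap to compound 1 lies within the usual scatter of this measurement, so the two compounds cannot be separated on these data. Compound 3 `CC1=C(C(=O)Nc2ccc([N+](=O)[O-])cc2)C(c2cccc([N+](=O)[O-])c2)N=C(SCc2ccc(F)cc2)N1` has not yet been measured. It differs from compound 2 at a single place: 4-fluorophenyl in place of 2-chlorophenyl on a saturated chain carbon bound to a sulfur. Going by the values given here, no two measured compounds differ by exactly this change, so the data offer no direct guide to its size, and the two measured values themselves sit close together. The step from compound 2 to compound 3 is therefore expected to be small, a number 3.7 percentage points higher from compound 2 to compound 3 (within the scatter), with no direction claimed beyond the scatter. Compound 3 is estimated to give 13% in this assay, within a range from 0% to 28%.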

Compound 3, a percentage reported as inhibition, in the whole organism at one dose (the size of the read-out at that dose, not a potency): 17.5%
Compound 3: the middle estimate sits 4.5 percentage points below what was measured; the measured number falls inside the stated range.
By their numbers in this assay, from the lowest: compounds 2, 1 and 3 (each within the scatter of the next).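

In this assay, going by these compounds alone, 4-fluorophenyl in place of 2-chlorophenyl on a saturated chain carbon bound to a sulfur gives the first single-place step at this position (a number 8.2 percentage points higher from compound 2 to compound 3 (within the scatter)), so this exchange cannot be separated from the usual scatter. A second single-place step appears on a saturated ring carbon, where 3-nitrophenyl stands in place of 4-bromophenyl (no change at the digits printed from compound 1 to compound 3 (within the scatter)), so with 4-fluorophenyl on the chain these two groups cannot be told apart either. No independent measurement bears on these readings.

The compounds shown leave open whether any group at the chain position can move the reading beyond the scatter, since only two substituted phenyl rings appear there. A carboxylic acid or an amine on that ring, or a longer chain before it, remains untested in the part shown here.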